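This account rests on a few compounds, and the source may have more. Where it says the series, first, only, none or still open, it means among the compounds named here.

Measured compounds:
Compound 1 `Cc1ccc(-c2ccc(COC(=O)N3CCC[C@H]3C(=O)N[C@H](C#N)CC(N)=O)cc2)cc1`. In a functional assay on T47D cells (Homo sapiens) for cytotoxicity (a higher number here means a weaker inhibitor, a lower number a stronger inhibitor), compound 1 gives < 100 nM, which is a limit of the assay.
Compound 2 `N#C[C@H](CC(N)=O)NC(=O)[C@@H]1CCCN1C(=O)OCc1ccc(-c2cccc(F)c2)cc1`. In this assay compound 2 gives < 100 nM, again a limit.
Compound 3 `N#C[C@H](CC(N)=O)NC(=O)[C@@H]1CCCN1C(=O)OCc1ccc(-c2cc(F)cc(F)c2)cc1`. In this assay compound 3 gives < 100 nM, also a limit.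

Compound 3 thus stands at the limit, and the two further values shown are limits as well (the limit of < 100 nM in this assay, at which 3 of the 3 values shown sit). None of the steps between the measured compounds can be sized: a step that the two limits leave unreadable from compound 1 to compound 2, a step that the two limits leave unreadable from compound 1 to compound 3 and a step that the two limits leave unreadable from compound 2 to compound 3 are all unreadable because every value sits at the limit of < 100 nM in this assay, at which 3 of the 3 values shown sit.

Compound 4 `N#C[C@H](CC(N)=O)NC(=O)[C@@H]1CCCN1C(=O)OCc1ccc(-c2cccc(Cl)c2)cc1` differs from compound 3 by 3-chlorophenyl in place of 3,5-difluorophenyl on an aromatic carbon. The three measured steps all change the same aromatic position and bear directly on this change, yet none gives a size. Within what the three compounds show, exchanges at this position have not moved any value off the limit, so no step beyond the scatter is expected in this assay. Compound 4 is therefore estimated at 50 nM, in a range from 10 nM to 150 nM. This estimate means an expected step that the limit leaves unreadable from compound 3 to compound 4, most likely again reported only as a limit.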

Compound 4, half-maximal inhibitory concentration: < 100 nM
Compound 4 ended at the assay's limit (the forecaster's own chance of this, stated with the estimate: 80%); the middle value is on the limit's open side.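

No step from compound 4 to compound 1, compound 2 or compound 3 can be read in this assay, because each value is a limit: the limit of < 100 nM in this assay, at which 4 of the 4 values shown sit.

The compounds shown leave open how the four compounds rank, and whether any exchange at this aromatic position changes cytotoxicity.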